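Benzamido for Nitro on the Shared Phthalimide Fused Ring

The source may hold more compounds than are shown below. What is called first, only, known or untested is meant among the compounds shown, and "the series" means these compounds.

Four compounds share a core in which an aniline nitrogen is linked through a single carbon to an imide of a fused two-ring system. Compound 1 `CCN(CC)c1ccc(NCN2C(=O)c3ccccc3C2=O)c(C)c1` carries a diethylamino group and a methyl group on its aniline ring; in an assay on isolated protein for inhibition of ribosomal protein S6 kinase alpha-2 (Homo sapiens), read by fluorescence, with a stated time of 20 min (on this read-out lower numbers stand for stronger inhibition and higher numbers for weaker inhibition), compound 1 gives 860 nM. Compound 2 `Cc1ccc(NCN2C(=O)c3ccc([N+](=O)[O-])cc3C2=O)cc1` has a methyl on the aniline and a nitro group on the fused ring; in this assay compound 2 gives "not determined" (no result reported), so no number is available for it. Compound 3 `CCOc1ccc(NCN2C(=O)c3ccc([N+](=O)[O-])cc3C2=O)cc1` keeps the nitro group but carries an ethoxy group on the aniline; in this assay compound 3 gives 2830 nM, the higher of the two numbers reported, and its gap to compound 1 lies beyond the usual scatter.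

Compound 4 `CCOc1ccc(NCN2C(=O)c3ccc(NC(=O)c4ccccc4)cc3C2=O)cc1` differs from compound 3 in one place: benzamido in place of nitro on an aromatic carbon. Going by the values given here, no measured pair shows this change, so the direction is open. The step from compound 3 to compound 4 is expected to be a 1.1-fold lower number from compound 3 to compound 4 (0.05 log units; within the scatter), that is, no change beyond the scatter. Compound 4 is therefore estimated at 2500 nM, within a range from 700 nM to 9000 nM.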

Compound 4, half-maximal inhibitory concentration: 4580 nM
For compound 4 the middle estimate is 1.8-fold (0.26 log units) below the measured one, within the range that was stated.
By their numbers in this assay, from the lowest: compound 1; then compounds 3 and 4 (each within the scatter of the next).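

In this assay, benzamido in place of nitro on this aromatic carbon gives a 1.6-fold higher number from compound 3 to compound 4 (0.21 log units; within the scatter) for the shared core with the ethoxy group on the aniline. The change replaces 3 heavy atoms and no ring with 9 heavy atoms and a six-membered aromatic ring, and it adds a hydrogen-bond donor, yet the two compounds cannot be told apart on this read-out, so this position takes the larger group without a clear shift in the number. No measurement is available that explains why these two groups read alike.

Going by these compounds, how an amine or a carboxylic acid on this carbon would read remains open. So does whether the aromatic ring of benzamido matters, which an acetamido group could test.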